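The source may hold more compounds than are shown below. What is called first, only, known or untested is meant among the compounds shown, and "the series" means these compounds.

Compound 1, `COc1ccc(-c2c(-c3ccc(S(C)(=O)=O)cc3)oc3ccccc3c2=O)cc1`, carries a 4-methoxyphenyl group on the shared core. In an assay on isolated protein for inhibition of prostaglandin G/H synthase 1 (Mus musculus), tested at 10 ug/mL (a lower number here means less inhibition, a higher number more inhibition at the concentration tested (going by the name of the read-out)), compound 1 gives < 5%, which is a limit of the assay rather than a number. Compound 2, `CS(=O)(=O)c1ccc(-c2oc3ccccc3c(=O)c2-c2ccc(F)cc2)cc1`, is measured in this assay at < 8%, again a limit. Compound 3, `CS(=O)(=O)c1ccc(-c2oc3ccccc3c(=S)c2-c2ccc(F)cc2)cc1`, gives < 5% in this assay, also a limit. Among the compounds with values here, compound 1 therefore stands at the limit described by the limit of < 5% in this assay, at which 2 of the 3 values shown sit, while the remaining value stands at the limit described by the limit of < 8% in this assay, at which 1 of the 3 values shown sits; no measured compound here provides an actual number.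

Compound 4, `CS(=O)(=O)c1ccc(-c2oc3ccccc3c(=O)c2-c2cccc(Cl)c2)cc1`, is not yet measured. It differs from compound 1 in one place: 3-chlorophenyl in place of 4-methoxyphenyl on an aromatic carbon. Within the data shown here, the only step between measured compounds that touches the same position is a step that the two limits leave unreadable from compound 1 to compound 2, whose size the two limits leave unreadable. Among the measured compounds shown here, no measured step thus gives a direction or a size for the change from compound 1 to compound 4, and every value shown sits at a limit. Compound 4 is accordingly expected to give a limit as well, with an estimated step that the limit leaves unreadable from compound 1 to compound 4. The estimate for compound 4 in this assay is 3%, with a range from 0% to 10%.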

Compound 4, a percentage reported as inhibition, at one concentration (the size of the read-out at that concentration, not a potency): < 5%
Compound 4 gave a limit, no number; the forecaster's own chance of this, stated with the estimate: 80%; the middle value does not contradict the limit.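

Compound 4, like compound 1 and compound 2, is reported only as a limit and not as a number, so neither step to compound 4 can be read in this assay. The compounds shown leave open whether 3-chlorophenyl, 4-methoxyphenyl and 4-fluorophenyl on the shared core differ at all in this assay, and if so, by how much.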